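Swapping chloro for trifluoromethyl on the benzyl ring

The source may hold more compounds than are shown below. What is called first, only, known or untested is meant among the compounds shown, and "the series" means these compounds.

Compound 1 `O=c1nc(N2CCN(NCC3CCCCC3)CC2)sc2c([N+](=O)[O-])cc(C(F)(F)F)cc12` carries a cyclohexylmethyl group on its hydrazine nitrogen; in an ADME assay on Vero cells (Chlorocebus sabaeus) for cytotoxicity, read by MTT assay, with a stated time of 72 h (a lower number here means that less compound is tolerated, a higher number that more compound is tolerated), compound 1 gives 29.3 ug/mL. Compound 2 `O=c1nc(N2CCN(NCc3ccc(C(F)(F)F)cc3)CC2)sc2c([N+](=O)[O-])cc(C(F)(F)F)cc12` replaces the cyclohexyl by 4-(trifluoromethyl)phenyl. In this assay compound 2 reaches only the limit of > 64 ug/mL, not a number. The step of an at least 2.1-fold higher number from compound 1 to compound 2 (0.33 log units; beyond the scatter) is therefore known only as a minimum, because of the limit of > 64 ug/mL in this assay, at which 1 of the 2 values shown sits. Compound 3 `O=c1nc(N2CCN(NCc3ccc(Cl)cc3)CC2)sc2c([N+](=O)[O-])cc(C(F)(F)F)cc12` differs from compound 2 in one place: chloro in place of trifluoromethyl on an aromatic carbon. For the measured compounds named here, no measured step touches this change; the single measured step swaps a whole ring, not one substituent on it, so nothing here points to a direction. Compound 3 is expected to stay within the scatter of compound 2, a step of a number no higher from compound 2 to compound 3 (the limit leaves the size open), and its estimate in this assay is 64 ug/mL, between 30 ug/mL and 130 ug/mL.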

Compound 3, half-maximal cytotoxic concentration: > 64 ug/mL
Compound 3 ended at the assay's limit (the forecaster's own chance of this, stated with the estimate: 55%); the middle value sits exactly at the limit.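

In this assay, the change from trifluoromethyl to chloro cannot be read as a step between compound 2 and compound 3, because neither compound gives a number, only a limit of the assay: the limit of > 64 ug/mL in this assay, at which 2 of the 3 values shown sit.

The new result does add a second ring swap that points the same way as the first: 4-chlorophenyl in place of cyclohexyl gives an at least 2.1-fold higher number from compound 1 to compound 3 (0.33 log units; beyond the scatter). A higher number here means that more compound is tolerated, so the trifluoromethyl and chloro versions of the benzyl ring both beat the cyclohexyl group of compound 1, and none of the three compounds goes against this.

Going by these compounds, it remains open whether a benzyl ring carrying no substituent, or one carrying a methoxy group or an amine, would behave the same way. On these data alone, how far the true values of compound 2 and compound 3 lie beyond the limit also remains open.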